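The compounds below may be only part of what the source reports. "The series", "measured", "known", "first", "only" and "open" are said of these compounds alone.

Measured so far in a functional assay on EA.hy 926 cells (Homo sapiens) for cytotoxicity, read by MTT assay, with stated times of 24 h and 12 h, tested at 12.5 uM; on this read-out higher numbers stand for a stronger effect at the one concentration tested and lower numbers for a weaker effect:
compound 1 `Cc1nc(C)c(C(=O)Oc2ccccc2/C=C/C(=O)O)nc1C`: 45.7%
compound 2 `COc1ccc(OC(=O)c2nc(C)c(C)nc2C)c(/C=C/C(=O)O)c1`: 21.7%

Compound 2 stands lowest of the two numbers; the nearest is compound 1, higher beyond the scatter. Compound 3 `Cc1nc(C)c(C(=O)Oc2ccc(Cl)cc2/C=C/C(=O)O)nc1C` differs from compound 2 by chloro in place of methoxy on an aromatic carbon. For the measured compounds named here, the one measured step that bears on this is a number 24 percentage points lower from compound 1 to compound 2 (beyond the scatter), where methoxy replaced hydrogen. Removing the methoxy again, though for chloro rather than hydrogen, is expected to recover part of that loss rather than all of it. Compound 3 is thus expected at 35% (range 15% to 55%). This amounts to an expected step of a number 13.3 percentage points higher from compound 2 to compound 3 (beyond the scatter).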

Compound 3, a percentage reported as activity, at one concentration (the size of the read-out at that concentration, not a potency): 6.9%
Estimate against measurement, compound 3: 28.1 percentage points above, outside the stated range (below it).
By their numbers in this assay, from the lowest: compound 3; then compound 2; then compound 1.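

In this assay, with the substituent para to a large group, chloro in place of hydrogen gives a number 38.8 percentage points lower from compound 1 to compound 3 (beyond the scatter) and so goes further down than methoxy did, while chloro in place of methoxy gives a number 14.8 percentage points lower from compound 2 to compound 3 (beyond the scatter) as a further loss. The drop at this position therefore does not belong to methoxy alone: both substituents stand under hydrogen, and chloro stands lowest of the three. No measured evidence accounts for this order.

On these data alone, whether an amine or a hydroxyl at this position would stand nearer hydrogen or chloro remains open. So does whether the same order holds at other carbons of this ring.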